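The source may report more compounds than this note shows. Statements on the series, on what has been measured and on what is new or still open speak of the compounds shown alone.

Measured in a functional assay on HeLa cells (Homo sapiens) for antiproliferative activity, read by CCK-8 assay, with a stated time of 48 h (a higher number here means a weaker inhibitor, a lower number a stronger inhibitor), as follows:

Compound 1 `COc1ccc(/C=C\c2cc(OC)c(OC)c(OC)c2)cc1OCc1ccc(CNC(C)(C)C(=O)O)cc1` gives > 10000 nM as a limit of the assay
Compound 2 `COc1ccc(/C=C\c2cc(OC)c(OC)c(OC)c2)cc1OCc1ccc(CN2CC(C(=O)O)C2)cc1` gives 6500 nM
Compound 3 `COc1ccc(/C=C\c2cc(OC)c(OC)c(OC)c2)cc1OCc1ccc(CNCCN(C)C)cc1` gives 9400 nM

Compound 3 stands within the scatter of compound 2 (a 1.4-fold higher number from compound 2 to compound 3 (0.16 log units; within the scatter)), while the figure for compound 1 is only a limit. The step to compound 4 `COc1ccc(/C=C\c2cc(OC)c(OC)c(OC)c2)cc1OCc1ccc(CN2CCCCC2C(=O)NCCN)cc1` keeps the shared core and puts 2-((2-aminoethyl)carbamoyl)piperidin-1-yl in place of (2-(dimethylamino)ethyl)amino on a saturated chain carbon bound to an aromatic carbon. Two further measured steps change this same place. Both an at least 1.5-fold lower number from compound 1 to compound 2 (0.18 log units; that floor lies within the scatter) and an at least 1.0-fold lower number from compound 1 to compound 3 (0.02 log units; that floor lies within the scatter) are floors within the scatter. None of the three steps moves the number beyond the scatter, so no step beyond the scatter is expected in this assay here. For the measured compounds named here, no measured compound carries the entering group, however, so the expected range is kept wide. Compound 4 is estimated at 6000 nM as the middle value. The estimated range for compound 4 runs from 2000 nM to 15000 nM for a single measurement. This estimate means an expected 1.6-fold lower number from compound 3 to compound 4 (0.19 log units; within the scatter) in all. Going by the values given here, the assay may also return only a limit for compound 4, as expressed by the limit of > 10000 nM in this assay, at which 1 of the 3 values shown sits, for the series so far.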

Compound 4, half-maximal inhibitory concentration: 7300 nM
Compound 4: middle estimate off by 1.2-fold (0.09 log units), on the low side; the range from low to high includes it.
By their numbers in this assay, from the lowest: compounds 2, 4 and 3 (each within the scatter of the next). At a limit, above all of these: compound 1.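

In this assay, putting 2-((2-aminoethyl)carbamoyl)piperidin-1-yl on a saturated chain carbon bound to an aromatic carbon gives a 1.3-fold lower number from compound 3 to compound 4 (0.11 log units; within the scatter), and setting it in place of 3-carboxyazetidin-1-yl gives a 1.1-fold higher number from compound 2 to compound 4 (0.05 log units; within the scatter). For the compounds shown here, this place therefore carries a group with a six-membered non-aromatic ring and an amide without the number leaving the scatter of the open-chain diamine or the azetidine acid, which the earlier compounds could not show. Against compound 1 only a floor can be read, an at least 1.3-fold lower number from compound 1 to compound 4 (0.13 log units; that floor lies within the scatter), and compound 1 stays at a limit: the limit of > 10000 nM in this assay, at which 1 of the 4 values shown sits.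

From the compounds shown here alone, whether any group at this place moves the number beyond the scatter remains open. So does the share of the piperidine ring and of the aminoethyl amide in this result, which a plain piperidine or a longer aminoalkyl chain would address.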